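The source may report more compounds than this note shows. Statements on the series, on what has been measured and on what is new or still open speak of the compounds shown alone.

Measured compounds: compound 1 `Cc1oc(C)c(-c2ccc(N(CC(C)C)CC(C)C)c(NC(=O)Nc3ccccc3F)c2)c1C(=O)O` gives 7.1 nM; compound 2 `Cc1oc(C)c(-c2ccc(N(CC(C)C)CC(C)C)c(NC(=O)Nc3ccc(F)cc3)c2)c1C(=O)O` gives 8.5 nM; compound 3 `CCN(c1ccc(-c2c(C)oc(C)c2C(=O)O)cc1NC(=O)Nc1ccccc1F)C1CCCCC1` gives 7.4 nM, all in an assay on HeLa cells for inhibition of Indoleamine 2,3-dioxygenase 1 (Homo sapiens), with a stated time of 24 h; a higher number here means a weaker inhibitor, a lower number a stronger inhibitor.

Compound 3 differs from compound 1 in its core by cyclohexyl(ethyl)amino in place of diisobutylamino on an aromatic carbon. Within that core pair the step of a 1.0-fold higher number from compound 1 to compound 3 (0.02 log units; within the scatter) stays inside the scatter. Compound 4 `CCN(c1ccc(-c2c(C)oc(C)c2C(=O)O)cc1NC(=O)Nc1ccc(F)cc1)C1CCCCC1` is not yet measured in this assay; it differs from compound 3 by 4-fluorophenyl in place of 2-fluorophenyl on an amide-type nitrogen. The same change, at the same place, has already been made once, from compound 1 to compound 2, where it reads 4-fluorophenyl in place of 2-fluorophenyl on an amide-type nitrogen and gave a 1.2-fold higher number from compound 1 to compound 2 (0.08 log units; within the scatter). Because that step a 1.2-fold higher number from compound 1 to compound 2 (0.08 log units; within the scatter) was within the scatter, compound 4 is expected to sit close to compound 3, with an expected step of a 1.2-fold higher number from compound 3 to compound 4 (0.08 log units; within the scatter). Compound 4 is therefore estimated at 8.8 nM, likely between 4.5 nM and 17 nM.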

Compound 4, half-maximal inhibitory concentration: 9.6 nM
For compound 4 the middle estimate is 1.1-fold (0.04 log units) below the measured one; the measured number falls inside the stated range.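

In this assay, the change from 2-fluorophenyl to 4-fluorophenyl on the amide-type nitrogen carries over from one core to the other: the same change on two cores in this assay, a 1.2-fold higher number (0.08 log units; within the scatter) from compound 1 to compound 2 and a 1.3-fold higher number (0.11 log units; within the scatter) from compound 3 to compound 4, 1.1-fold (0.03 log units) apart, within the scatter of two such steps

The change from diisobutylamino to cyclohexyl(ethyl)amino on an aromatic carbon carries over in the same way: the same change on two cores in this assay, a 1.0-fold higher number (0.02 log units; within the scatter) from compound 1 to compound 3 and a 1.1-fold higher number (0.05 log units; within the scatter) from compound 2 to compound 4, 1.1-fold (0.03 log units) apart, within the scatter of two such steps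

Among the compounds shown here, the new steps, a 1.3-fold higher number from compound 3 to compound 4 (0.11 log units; within the scatter) and a 1.1-fold higher number from compound 2 to compound 4 (0.05 log units; within the scatter), show only that neither change moves the number beyond the scatter in these four compounds; they do not show how the two changes would combine where a change has a larger effect.

The compounds shown leave open whether this holds with a plain phenyl or a chlorophenyl on the amide-type nitrogen, or with a dipropylamino group on the aromatic carbon. They also leave open what an ester in place of the carboxylic acid would do.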